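Enaminone series: cyclohexylamino in place of (sec-butyl)amino

This account rests on a few compounds, and the source may have more. Where it says the series, first, only, none or still open, it means among the compounds named here.

Compound 1 `CCC(C)NC(=C\C(=O)/C=C/c1ccc(O)c(OC)c1)/C=C/c1ccc(O)c(OC)c1` has been measured in a functional assay on Caco-2 cells (Homo sapiens), read by fluorescence, tested at 10 uM (a higher number here means a weaker effect of the compound at the concentration tested, a lower number a stronger effect), and gives 66%. Going by the values given here, compound 2 `COc1cc(/C=C/C(=O)CC(=O)/C=C/c2ccc(OC(C)=O)c(OC)c2)ccc1OC(C)=O`, the only other compound with a number, gives 90% in this assay. Of the two numbers, compound 1 stands at the lower end; the gap to compound 2 is beyond the scatter, so compound 1 shows the stronger effect of the two at the tested concentration. Among the compounds with values here, no step between measured compounds that differ in a single place is available, so the size of any one change cannot be read from the series itself.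

Compound 3 `COc1cc(/C=C/C(=O)/C=C(/C=C/c2ccc(O)c(OC)c2)NC2CCCCC2)ccc1O` has not yet been measured in this assay. It differs from compound 1 by cyclohexyl in place of sec-butyl on an amine nitrogen. The leaving and entering groups carry no donors, no acceptors and no charge; the change is confined to the carbon substituent on the amine nitrogen. Within the data shown here, with no measured step of this kind to lean on, no shift beyond the scatter is expected in either direction, and the step from compound 1 to compound 3 in this assay is estimated at a number 4 percentage points lower from compound 1 to compound 3 (within the scatter). For compound 3 the expected value in this assay is 62%, with a range from 45% to 80%. The range is kept wide: compound 2 differs from compound 1 in several places at once and gives no guidance on this single change.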

Compound 3, a percentage reported as activity, at one concentration (the size of the read-out at that concentration, not a potency): 63%
Compound 3: the middle estimate sits 1 percentage points below what was measured, within the range that was stated.
By their numbers in this assay, from the lowest: compounds 3 and 1 (each within the scatter of the next); then compound 2.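

In this assay, the series now has its first step that differs in one place: a number 3 percentage points lower from compound 1 to compound 3 (within the scatter). On an amine nitrogen whose other neighbours are the double-bonded chain carbon, replacing sec-butyl with cyclohexyl, which brings in a six-membered non-aromatic ring of carbon only, therefore leaves the read-out within the scatter, though this rests on a single pair and sets no trend with the size or shape of the group. No available measurement bears on why these two groups read alike.

Still open, from the compounds shown here alone, is whether this position accepts groups of a different kind as readily, for example a methyl, a benzyl or a chain ending in a carboxylic acid, since both groups compared here are carbon-only and carry no donors, acceptors or charge. Going by these compounds alone, also open is how much the hydroxyl and methoxy groups on the shared core contribute, as no step that differs in one place touches either of them.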